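A few compounds are considered here, and "the series" means these few. Any claim that something is new, unique, unknown or untested is made for them only; others in the source may bear on it.

Measured so far in a functional assay on CCRF-CEM cells (Homo sapiens) for antiproliferative activity; a higher number here means a weaker inhibitor, a lower number a stronger inhibitor:
- compound 1 `COc1cc(C(=O)c2ccc3c(ccn3C)c2)cc(OC)c1OC`: 18 nM
- compound 2 `COc1cc(OC)cc(C(=O)c2ccc3c(ccn3C)c2)c1`: 1690 nM
- compound 3 `COc1ccnc(OC)c1C(=O)c1ccc2c(ccn2C)c1`: 1010 nM

Compound 1 has the lowest number of the three, and it is the strongest inhibitor here at 18 nM. Compound 3 is nearest at 1010 nM, and compound 2 is furthest at 1690 nM; both lie beyond the scatter from it.

The next compound to be tested in this assay is compound 4 `COc1cc(C(=O)c2ccc3[nH]ccc3c2)cc(OC)c1OC`, with hydrogen in place of methyl on an aromatic nitrogen.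

Among the compounds with values here, only one step between measured compounds is available, and it is not at this place. It replaces methoxy with hydrogen on an aromatic carbon and is large: a 94-fold higher number from compound 1 to compound 2 (1.97 log units; beyond the scatter). Compound 4 keeps all the methoxy groups of compound 1, so that step does not carry over in size. Within the data shown here, no measured step changes the group on the nitrogen, so the direction below is an expectation with little direct support. A modest loss is expected, much smaller than the step to compound 2, and no change beyond the scatter remains possible.

The expected step is a 2.2-fold higher number from compound 1 to compound 4 (0.35 log units; beyond the scatter). For compound 4 the estimated value is 40 nM, with an expected range of 14 nM to 140 nM.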

Compound 4, half-maximal inhibitory concentration: 225 nM
Compound 4: middle estimate off by 5.6-fold (0.75 log units), on the low side; the measured number lies above the stated range.
By their numbers in this assay, from the lowest: compound 1; then compound 4; then compounds 3 and 2 (each within the scatter of the next).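

In this assay, the group on the aromatic nitrogen of the five-membered aromatic ring proves to matter: hydrogen in place of methyl gives a 13-fold higher number from compound 1 to compound 4 (1.10 log units; beyond the scatter), a large step beyond the scatter. Within the data shown here, the only step readable before this lay at a methoxy group on an aromatic carbon, a 94-fold higher number from compound 1 to compound 2 (1.97 log units; beyond the scatter), so the number for compound 1 now depends on a second place in the molecule, even with all the methoxy groups kept. The data at hand offer no measurement that accounts for this loss on going from methyl to hydrogen.

Only methyl and hydrogen are shown on this nitrogen, so it stays open whether a longer chain such as ethyl, or a chain ending in an amine or a carboxylic acid, would keep the number of compound 1 or move it further in either direction. Also open is whether the step keeps its size with other methoxy patterns on the shared core, as the compounds shown offer no second pair that differs only at this nitrogen.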